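The source may hold more compounds than are shown below. What is called first, only, known or untested is meant among the compounds shown, and "the series" means these compounds.

In a functional assay on MDA-MB-231 cells (Homo sapiens) for cytotoxicity, read by MTT assay, with a stated time of 48 h (on this read-out lower numbers stand for stronger inhibition and higher numbers for weaker inhibition), compound 1 `O=C(NCCCCC(c1ccc(F)cc1)c1ccc(F)cc1)Nc1ccc(Cl)cc1` gives 7680 nM. Compound 2 `Cc1ccc(NC(=O)NCCCCC(c2ccc(F)cc2)c2ccc(F)cc2)cc1` gives > 20000 nM, which is a limit and not a number. Compound 3 `CC(=O)Nc1ccc(NC(=O)NCCCCC(c2ccc(F)cc2)c2ccc(F)cc2)cc1` gives > 20000 nM, likewise a limit. Compound 3 therefore stands at the limit of > 20000 nM in this assay, at which 2 of the 3 values shown sit, and its true value is not known.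

Compound 4 `O=C(NCCCCC(c1ccc(F)cc1)c1ccc(F)cc1)Nc1cccc(C(F)(F)F)c1` differs from compound 3 in one place: 3-(trifluoromethyl)phenyl in place of 4-acetamidophenyl on an amide-type nitrogen. The acetamido group that leaves has already been met in the step of an at least 2.6-fold higher number from compound 1 to compound 3 (0.41 log units; beyond the scatter), with acetamido in place of chloro, and methyl in place of chloro gave an at least 2.6-fold higher number from compound 1 to compound 2 (0.41 log units; beyond the scatter). The step that the two limits leave unreadable from compound 2 to compound 3 adds nothing that can be read. For the measured compounds named here, no measured step brings in 3-(trifluoromethyl)phenyl, so the expectation rests on one comparison: compound 1, at 7680 nM, is the only compound with a readable number. A modest step to a lower number is expected, an at least 2.2-fold lower number from compound 3 to compound 4 (0.34 log units; beyond the scatter), although a second limit remains possible. For compound 4 the estimated value is 9000 nM, with an expected range of 3500 nM to 20000 nM.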

Compound 4, half-maximal inhibitory concentration: 3380 nM
Compound 4: middle estimate off by 2.7-fold (0.43 log units), on the high side; the whole stated range lies above it.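

On the amide-type nitrogen, 3-(trifluoromethyl)phenyl in place of 4-acetamidophenyl gives an at least 5.9-fold lower number from compound 3 to compound 4 (0.77 log units; beyond the scatter), and in place of 4-methylphenyl it gives an at least 5.9-fold lower number from compound 2 to compound 4 (0.77 log units; beyond the scatter). Against 4-chlorophenyl, the only earlier group with a readable number, it gives a 2.3-fold lower number from compound 1 to compound 4 (0.36 log units; beyond the scatter), so this place can hold a group that improves on compound 1 and not only groups that lose to it. The two larger steps give only a minimum size: the limit of > 20000 nM in this assay, at which 2 of the 4 values shown sit.

On these data alone, whether the gain follows the trifluoromethyl group or its place on the ring stays open, and a comparison of 4-(trifluoromethyl)phenyl and 3-chlorophenyl would separate the two. Also open, as far as these compounds go, is how a nitrile, an amine or a carboxylic acid on this phenyl ring, or a longer chain in the shared core, would read in this assay.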